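This account rests on a few compounds, and the source may have more. Where it says the series, first, only, none or still open, it means among the compounds named here.

Series notes on the cytotoxicity set. Compound 1 `COc1ccc(/C=C/C(=O)CC(=O)/C=C/c2ccc(O)c(OC)c2)cc1` in an ADME assay on HEK293 cells (Homo sapiens) for cytotoxicity, read by resazurin assay, with a stated time of 16 h (on this read-out higher numbers stand for an effect only at larger amounts of compound and lower numbers for an effect already at smaller amounts), gives 79000 nM. Compound 2 `COc1ccc(/C=C/C(=O)CC(=O)/C=C/c2ccc(O)cc2)cc1` in this assay gives 400000 nM. The change from compound 1 to compound 2 is hydrogen in place of methoxy on an aromatic carbon and made a 5.1-fold higher number from compound 1 to compound 2 (0.70 log units; beyond the scatter). Compound 3 `COc1cc(/C=C/C(=O)CC(=O)/C=C/c2ccc(OCC=C(C)C)c(OC)c2)ccc1OCC=C(C)C` in this assay shows only a limit, > 1000000 nM; this is the limit of > 1000000 nM in this assay, at which 1 of the 3 values shown sits. The difference between the core of compound 3 and the core of compound 1 is not broken down here. Compound 4 `COc1cc(/C=C/C(=O)CC(=O)/C=C/c2ccc(OCC=C(C)C)cc2)ccc1OCC=C(C)C` is not yet measured; from compound 3 it differs by hydrogen in place of methoxy on an aromatic carbon, the same kind of change as from compound 1 to compound 2, though here the place is ortho to a (3-methylbut-2-en-1-yl)oxy group rather than ortho to a hydroxy group. The earlier step, a 5.1-fold higher number from compound 1 to compound 2 (0.70 log units; beyond the scatter), points the same way for compound 4, which is expected to show a step that the limit leaves unreadable from compound 3 to compound 4. Compound 4 is estimated at 1500000 nM, between 700000 nM and 4000000 nM, with a limit again the likely outcome.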

Compound 4, half-maximal effective concentration: > 500000 nM
Compound 4 was reported as a limit; the forecaster's own chance of this, stated with the estimate: 80%; the middle value does not contradict the limit.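

Going by these compounds alone, compound 3 and compound 4 both stand only as limits in this assay, and no step between them can be read. The compounds shown leave open what hydrogen in place of methoxy does when ortho to a (3-methylbut-2-en-1-yl)oxy group.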